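The source may report more compounds than this note shows. Statements on the series, on what has been measured and on what is new or still open speak of the compounds shown alone.

In a functional assay on SMMC-7721 cells (Homo sapiens) for inhibition, read by MTT assay, with a stated time of 48 h (a higher number here means a weaker inhibitor, a lower number a stronger inhibitor), compound 1 `O=C(Nc1ccccn1)Nc1cc(-c2cncnc2)ccc1OC(F)(F)F` gives 21600 nM as a measured number. Compound 3 `COc1ccc(-c2cc(NC(=O)Nc3nccs3)cc(C(F)(F)F)c2)cn1` gives 36200 nM as a measured number too. Compound 2 `COc1ccc(-c2cc(NC(=O)Nc3ccncc3)cc(C(F)(F)F)c2)cn1` stands at > 300000 nM which is a limit of the assay and not a number.

Compound 4 `Cn1cnc(-c2cc(NC(=O)Nc3ccncc3)cc(C(F)(F)F)c2)c1` differs from compound 2 by 1-methyl-1H-imidazol-4-yl in place of 6-methoxypyridin-3-yl on an aromatic carbon with 1-methyl-1H-imidazol-4-yl in place of 6-methoxypyridin-3-yl on an aromatic carbon, meta to a trifluoromethyl group. Within the data shown here, the one measured step out of compound 2 is an at least 8.2-fold lower number from compound 2 to compound 3 (0.91 log units; beyond the scatter) and it lies at a different place, with 1,3-thiazol-2-yl in place of pyridin-4-yl on an amide-type nitrogen. Among the measured compounds shown here, compound 4 keeps the pyridin-4-yl, so that step does not carry over, and no measured pair changes the group at the new place. Only a small move toward a lower number is therefore expected in this assay for this change. The estimated step is an at least 1.5-fold lower number from compound 2 to compound 4 (0.17 log units; that floor lies within the scatter) and its size remains rough. For compound 4 the estimated value is 200000 nM with an expected range from 60000 nM to 600000 nM and a report of only a limit is quite possible.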

Compound 4, half-maximal inhibitory concentration: 235000 nM
Estimate against measurement, compound 4: 1.2-fold (0.07 log units) below; low and high end bracket the measured number.
By their numbers in this assay, from the lowest: compounds 1 and 3 (each within the scatter of the next); then compound 4. At a limit, above all of these: compound 2.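

In this assay, among these compounds, the first change at this aromatic carbon, meta to a trifluoromethyl group, gives an at least 1.2-fold lower number from compound 2 to compound 4 (0.10 log units; that floor lies within the scatter), with the pyridin-4-yl on the urea side kept. The floor of this step lies within the scatter, so it cannot establish that 1-methyl-1H-imidazol-4-yl is better than 6-methoxypyridin-3-yl, although compound 4 does give a measured number. For compound 2 the reading is a limit and not a number, so the full size of the step stays unknown: the limit of > 300000 nM in this assay, at which 1 of the 4 values shown sits.

Still open, on these data alone, is how 1-methyl-1H-imidazol-4-yl behaves when paired with 1,3-thiazol-2-yl on the amide-type nitrogen. Also open, as far as these compounds go, is what a non-ring group at this carbon, such as an amine or a carboxylic acid, would give in this assay.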